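Bromo in Place of Hydrogen on the Phenyl Ring of Compound 2

This account rests on a few compounds, and the source may have more. Where it says the series, first, only, none or still open, it means among the compounds named here.

Measured compounds:
- compound 1, `CC(=O)c1c(NNc2ccccc2)cc(C)oc1=O`: in a functional assay on the whole organism for inhibition, with Rattus norvegicus as the target, read by paw edema, with a stated time of 3 h, at a dose of 50 mg/kg (on this read-out higher numbers stand for more inhibition at the one dose given (going by the name of the read-out) and lower numbers for less inhibition), compound 1 gives 55.6%
- compound 2, `Cc1cc2nn(-c3ccccc3)c(C)c2c(=O)o1`: in this assay compound 2 gives 52.5%

Of the compounds shown here, two have been measured in this assay so far, and no step between compounds that differ in one place is available. Compound 2 stands with a number that lies within the scatter of the number of compound 1, so the two cannot be told apart on this read-out.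

Compound 3, `Cc1cc2nn(-c3ccc(Br)cc3)c(C)c2c(=O)o1`, has not yet been measured. It differs from compound 2 in one place: bromo in place of hydrogen on an aromatic carbon. Within the data shown here, nothing in the two measured compounds shows what such a change does in this assay, since no pair of measured compounds differs in this way.

With no guide from the data, the step from compound 2 to compound 3 is expected to stay within the scatter, in either direction, at about a number 0.5 percentage points lower from compound 2 to compound 3 (within the scatter). Compound 3 is therefore estimated to give 52% in this assay, with a range from 35% to 68%.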

Compound 3, a percentage reported as inhibition, in the whole organism at one dose (the size of the read-out at that dose, not a potency): 49.5%
Compound 3: middle estimate off by 2.5 percentage points, on the high side, within the range that was stated.
By their numbers in this assay, from the lowest: compounds 3, 2 and 1 (each within the scatter of the next).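

In this assay, bromo in place of hydrogen gives a number 3 percentage points lower from compound 2 to compound 3 (within the scatter), so compound 2 and compound 3 cannot be told apart on this read-out. Among these compounds, this is the first reading for this position, an aromatic carbon para to a large group on a six-membered aromatic ring of carbon only: a single bromine atom can enter there with no change in inhibition at the one dose given that stands clear of the scatter. No measurement is at hand that bears on the reason for this result.

A single step leaves open whether other groups in this place, such as methoxy, an amine or a carboxylic acid, would also leave the number within the scatter, and whether bromo on another carbon of the same ring would do so. The read-out gives the size of the effect at one dose and at one stated time, so it also leaves open whether compound 2 and compound 3 would still match at other doses or other times.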